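This account rests on a few compounds, and the source may have more. Where it says the series, first, only, none or still open, it means among the compounds named here.

Working notes on the series. Going by the values given here, in a functional assay on RS4-11 cells (Homo sapiens) for inhibition, read by CCK-8 assay, with a stated time of 48 h, tested at 20 uM (on this read-out higher numbers stand for more inhibition of growth at the one concentration tested and lower numbers for less inhibition of growth), compound 1 (`COc1ccc(Cc2nnc(NC(=O)/C(C#N)=C/c3ccccc3OS(=O)(=O)c3ccc(OC)cc3)s2)cc1`) gives 78% and compound 2 (`Cc1ccc(S(=O)(=O)Oc2ccccc2/C=C(\C#N)C(=O)Nc2nnc(Cc3cccc4ccccc34)s2)cc1`) gives 73% on the numbers so far, and these two values lie within the scatter of each other. Compound 3 (`COc1ccc(S(=O)(=O)Oc2ccccc2/C=C(\C#N)C(=O)Nc2nnc(Cc3cccc4ccccc34)s2)cc1`) differs from compound 2 by methoxy in place of methyl on an aromatic carbon, para to a large group (methoxy in place of methyl on an aromatic carbon). Among the compounds with values here, no measured pair shows this change alone, so any size given for it is an expectation only. In this assay no step beyond the scatter is expected, in either direction. The estimate gives a number 2 percentage points higher from compound 2 to compound 3 (within the scatter) and so stays within the scatter. For compound 3 the expected value is 75% with an estimated range from 62% to 87% at the one concentration tested.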

Compound 3, percent growth inhibition at one concentration: 78%
The estimate for compound 3 lay 3 percentage points below the measured number; the range from low to high includes it.
By their numbers in this assay, from the lowest: compounds 2, 1 and 3 (each within the scatter of the next).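

In this assay, methoxy in place of methyl on an aromatic carbon, para to a large group, gives a number 5 percentage points higher from compound 2 to compound 3 (within the scatter), so this read-out does not separate the 4-methylphenyl and 4-methoxyphenyl sulfonyl groups when naphthalen-1-yl is present. The second pair concerns the other end of the series: naphthalen-1-yl in place of 4-methoxyphenyl on the saturated chain carbon gives no change at the digits printed from compound 1 to compound 3 (within the scatter), so these two groups are not separated either when the 4-methoxyphenyl sulfonyl group is present. No independent data bear on why either pair reads alike.

From the compounds shown here alone, whether an amine or a carboxylic acid on that aromatic carbon would read apart from methyl and methoxy remains open. So does the effect of a longer chain in place of the saturated chain carbon, and a single-concentration read-out cannot show whether these compounds would separate at other concentrations.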